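Amide substituent swap on the shared core

The source may report more compounds than this note shows. Statements on the series, on what has been measured and on what is new or still open speak of the compounds shown alone.

Compound 1 `Cc1noc(C)c1-c1cnc(N)c(Oc2ccc(C(=O)NC3CCCC3)cc2)n1` is the lower of the two numbers shown: in a functional assay on HeLa cells (Homo sapiens) for inhibition, read by MTT assay, with a stated time of 72 h (a lower number here means a stronger inhibitor, a higher number a weaker inhibitor), compound 1 gives 9970 nM, while compound 2 `Cc1noc(C)c1-c1cnc(N)c(Oc2ccc(C(=O)Nc3ccccc3Cl)cc2)n1` gives 81300 nM in this assay, a change of an 8.2-fold higher number from compound 1 to compound 2 (0.91 log units; beyond the scatter). Compound 3 `Cc1noc(C)c1-c1cnc(N)c(Oc2ccc(C(=O)Nc3cccc(Cl)n3)cc2)n1` differs from compound 1 by 6-chloropyridin-2-yl in place of cyclopentyl on an amide-type nitrogen. For the measured compounds named here, the only measured step that bears on this is the one from compound 1 to compound 2, where an aromatic group replaced cyclopentyl on the same amide nitrogen, and it gave a clearly higher number. A comparable rise is therefore expected for compound 3, a 5.0-fold higher number from compound 1 to compound 3 (0.70 log units; beyond the scatter), estimated at 50000 nM with a range of 15000 nM to 160000 nM in this assay.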

Compound 3, half-maximal inhibitory concentration: 25500 nM
For compound 3 the middle estimate is 2.0-fold (0.29 log units) above the measured one; the range from low to high includes it.
By their numbers in this assay, from the lowest: compound 1; then compound 3; then compound 2.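

In this assay, the 6-chloropyridin-2-yl group on the amide-type nitrogen still does not match cyclopentyl, with a 2.6-fold higher number from compound 1 to compound 3 (0.41 log units; beyond the scatter). The choice of aromatic group also matters at this position, with a 3.2-fold lower number from compound 2 to compound 3 (0.50 log units; beyond the scatter), so replacing cyclopentyl with an aromatic ring does not raise the number by one fixed amount. Nothing shown explains these differences. The compounds shown leave open whether a piperidine ring or a longer alkyl chain on this nitrogen would give a lower number than compound 1. They also do not separate the effect of the ring nitrogen from that of the chlorine, which a plain pyridin-2-yl group could address.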